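Removing the Piperidinylmethylcarbonyl Group: Expected Cytotoxicity

This account rests on a few compounds, and the source may have more. Where it says the series, first, only, none or still open, it means among the compounds named here.

Compound 1 `O=C(CN1CCCCC1)Nc1ccc(-c2nc3cc(C(F)(F)F)ccc3[nH]2)cc1`: 31000 nM
Compound 2 `Cn1c(-c2ccc(NC(=O)CN3CCCCC3)cc2)nc2cc(C(F)(F)F)ccc21`: > 100000 nM

In an ADME assay on Vero cells (Chlorocebus sabaeus) for cytotoxicity (on this read-out higher numbers stand for lower toxicity in this test and lower numbers for higher toxicity in this test), compound 1 gives 31000 nM. For compound 2 the test returned only its limit, > 100000 nM, so compound 2 sits at the upper edge of the numbers seen (the limit of > 100000 nM in this assay, at which 1 of the 2 values shown sits). Going by the values given here, the single measured step, an at least 3.2-fold higher number from compound 1 to compound 2 (0.50 log units; beyond the scatter), concerns a different change. Compound 3 `Cn1c(-c2ccc(N)cc2)nc2cc(C(F)(F)F)ccc21` differs from compound 2 by hydrogen in place of ((piperidin-1-yl)methyl)carbonyl on a nitrogen on an aromatic ring. Among the compounds with values here, no measured step covers this change, so no direction can be drawn from the data. Compound 3 is therefore expected to give about 120000 nM, with a range of 35000 nM to 400000 nM. This estimate implies an expected step that the limit leaves unreadable from compound 2 to compound 3, likely within the scatter.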

Compound 3, half-maximal cytotoxic concentration: > 100000 nM
Compound 3: a limit, no number; the forecaster's own chance of this, stated with the estimate: 60%; the middle value lies beyond the limit too.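

Compound 2 and compound 3 both return only a limit in this assay, so no step can be read between them. The compounds shown leave open whether hydrogen in place of ((piperidin-1-yl)methyl)carbonyl changes this read-out at all, and in which direction.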